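The source may hold more compounds than are shown below. What is called first, only, known or untested is meant among the compounds shown, and "the series" means these compounds.

Compound 1 `CCC(=O)N(c1ccc(Cl)cc1)C1CCCC1N(C)C` gives 0.2 mg/kg
Compound 2 `CCC(=O)N(c1ccc(C)cc1)C1CCCC1N(C)C` gives 10 mg/kg; 10 mg/kg (2 entries)
Compound 3 `CCC(=O)N(c1ccc(F)cc1)C1CCCC1N(C)C` gives 0.08 mg/kg
Compound 4 `CCC(=O)N(c1ccc(F)c(Cl)c1)C1CCCC1N(C)C` has not yet been measured

Going by the values given here, compound 3 has the lowest number so far in a functional assay on the whole organism for antagonist activity, with Mus musculus as the target (on this read-out lower numbers stand for an effect already at smaller amounts and higher numbers for an effect only at larger amounts of compound), and so shows its effect at the smallest dose. Among the compounds with values here, its nearest neighbour is compound 1, and the only measured single change is a 2.5-fold lower number from compound 1 to compound 3 (0.40 log units; beyond the scatter) in this series. Compound 4 keeps the fluoro group of compound 3 and gains a chloro group, the change being chloro in place of hydrogen on an aromatic carbon on the same ring. Within the data shown here, no measured step adds a group in this way, so the evidence is indirect. Compound 1 with 0.2 mg/kg shows that a chloro group in place of the fluoro group keeps the number low, while compound 2 with 10 mg/kg; 10 mg/kg (2 entries) shows that a methyl group there goes with a much higher number. A modest rise in this assay is therefore expected, though the data cannot exclude a larger one. The expected change is a 2.5-fold higher number from compound 3 to compound 4 (0.40 log units; beyond the scatter) by this estimate. For compound 4 the estimated dose is 0.2 mg/kg with an expected range from 0.04 mg/kg to 1 mg/kg in repeated measurements.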

Compound 4, dose for half-maximal effect: 2 mg/kg
Estimate against measurement, compound 4: 10-fold (1.00 log units) below; the measured number lies above the stated range.
By their numbers in this assay, from the lowest: compound 3; then compound 1; then compound 4.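

In this assay the chloro group in place of hydrogen, on the aromatic carbon ortho to a fluoro group and meta to a large group, gives a 25-fold higher number from compound 3 to compound 4 (1.40 log units; beyond the scatter) and so marks this position as sensitive in this series. The earlier compounds shown here changed only the group at the place where compound 3 carries its fluoro group, whereas compound 4 shows that adding a single heavy atom at a second place on the ring can also move the dose by a large step. The information available gives no measured explanation for this rise.

From the compounds shown here alone, it remains open whether the rise is specific to chloro or would also appear with a second fluoro group, a methoxy group or an amine at this position. Going by these compounds, it is also open whether the chloro group would have the same effect on a ring with hydrogen in place of the fluoro group.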